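This account rests on a few compounds, and the source may have more. Where it says the series, first, only, none or still open, it means among the compounds named here.

Compound 1 `O=C(/C=C\Nc1ccc(Cl)cc1)c1cn(-c2ccccc2)nc1-c1ccccc1` and compound 3 `COc1cc(-c2nn(-c3ccccc3)cc2C(=O)/C=C\Nc2ccc(Cl)cc2)cc(OC)c1OC` share a core in which an anilino vinyl ketone hangs from a pyrazole; how their two cores differ is not broken down here. In a functional assay on PC-3 cells (Homo sapiens) for antiproliferative activity, read by MTT assay, with a stated time of 48 h (a higher number here means a weaker inhibitor, a lower number a stronger inhibitor), compound 1 gives 5200 nM, and compound 3 gives 11200 nM, the higher of the two numbers. Compound 2 `O=C(/C=C\Nc1ccc(C(F)(F)F)cc1)c1cn(-c2ccccc2)nc1-c1ccccc1` carries the change trifluoromethyl in place of chloro on an aromatic carbon relative to compound 1. Compound 2 reaches only a limit in this assay, > 50000 nM, which is a limit rather than a number. The step of an at least 9.6-fold higher number from compound 1 to compound 2 (0.98 log units; beyond the scatter) therefore has a size that can only be given as a lower bound, because of the limit of > 50000 nM in this assay, at which 1 of the 3 values shown sits.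

Compound 4 `COc1cc(-c2nn(-c3ccccc3)cc2C(=O)/C=C\Nc2ccc(C(F)(F)F)cc2)cc(OC)c1OC` is compound 3 with the same change, (trifluoromethyl in place of chloro on an aromatic carbon), and its number in this assay is not yet known. The change occurs twice among these four compounds, on the same place in each pair. Since compound 3 already sits above compound 1, the same step applied to compound 3 is expected to carry compound 4 past the limit of this assay. The step of an 8.9-fold higher number from compound 3 to compound 4 (0.95 log units; beyond the scatter) is the expected size, resting on the step seen from compound 1 to compound 2, an at least 9.6-fold higher number from compound 1 to compound 2 (0.98 log units; beyond the scatter). Compound 4 is therefore estimated at 100000 nM, with a likely range from 30000 nM to 400000 nM, and with a strong chance that this assay reports only a limit for it.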

Compound 4, half-maximal inhibitory concentration: > 50000 nM
Compound 4 was reported as a limit; the forecaster's own chance of this, stated with the estimate: 75%; the middle value lies beyond the limit too.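

In this assay, trifluoromethyl in place of chloro gives a higher number, meaning a weaker inhibitor, on the second core as well: the step is an at least 4.4-fold higher number from compound 3 to compound 4 (0.64 log units; beyond the scatter). Compound 4 gives > 50000 nM, which is a limit and not a number, and the step therefore fixes only the smallest size the change can have on this core. Both cores thus move in the same direction and beyond the usual scatter, which shows that the loss of activity carries over from one core to the other in these two pairs, but it does not show that the loss is equally large on both, and two pairs are too few to make a rule for the series: the same change on two cores in this assay, an at least 9.6-fold higher number (0.98 log units; beyond the scatter) from compound 1 to compound 2 and an at least 4.4-fold higher number (0.64 log units; beyond the scatter) from compound 3 to compound 4; the limit leaves it open whether they differ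

Going by these compounds, the step from compound 2 to compound 4, 3,4,5-trimethoxyphenyl in place of phenyl, cannot be read, because both of its ends are limits, and how the two cores compare with trifluoromethyl in place stays open: the limit of > 50000 nM in this assay, at which 2 of the 4 values shown sit. Also open is how another group on that same aromatic carbon, such as an amine or a carboxylic acid, would behave on either core.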